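Methoxy additions on two benzothiazole-amide cores

The source may hold more compounds than are shown below. What is called first, only, known or untested is meant among the compounds shown, and "the series" means these compounds.

Measured compounds:
compound 1, `COc1ccc(-c2cc(C(=O)Nc3nc4ccc(Cl)cc4s3)nc3cc(-c4ccccc4)nn23)cc1`: 3090 nM
compound 2, `COc1ccc(-c2cc(C(=O)Nc3nc4ccc(Cl)cc4s3)nc3cc(-c4ccccc4)nn23)cc1OC`: 6160 nM
compound 3, `COc1ccc2nc(NC(=O)c3cc(-c4ccc(OC)c(OC)c4)n4nc(-c5ccccc5)cc4n3)sc2c1`: 15800 nM

In a functional assay on A549 cells (Homo sapiens) for cytotoxicity, read by MTT assay, with a stated time of 48 h (a higher number here means a weaker inhibitor, a lower number a stronger inhibitor), compound 1 gives 3090 nM. Compound 2 carries methoxy in place of hydrogen on an aromatic carbon and gives 6160 nM, a step of a 2.0-fold higher number from compound 1 to compound 2 (0.30 log units; within the scatter). Compound 3 belongs to a different core; the difference between the core of compound 1 and the core of compound 3 is not broken down here. Compound 3 gives 15800 nM, and the step of a 2.6-fold higher number from compound 2 to compound 3 (0.41 log units; beyond the scatter) lies beyond the scatter.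

Compound 4, `COc1ccc2nc(NC(=O)c3cc(-c4cc(OC)c(OC)c(OC)c4)n4nc(-c5ccccc5)cc4n3)sc2c1`, has not been measured. It differs from compound 3 by methoxy in place of hydrogen on an aromatic carbon. Within the data shown here, this is the same kind of change as the one from compound 1 to compound 2, though the entering methoxy of compound 4 is also meta to a methoxy group, which was not so in compound 2. Among the measured compounds shown here, the only precedent is the step of a 2.0-fold higher number from compound 1 to compound 2 (0.30 log units; within the scatter), which stayed within the scatter. A step of about a 1.6-fold higher number from compound 3 to compound 4 (0.20 log units; within the scatter) is therefore expected for compound 4, resting on the earlier step of a 2.0-fold higher number from compound 1 to compound 2 (0.30 log units; within the scatter) and on the value of compound 3, 15800 nM. Compound 4 is estimated at 25000 nM, within 10000 nM to 60000 nM.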

Compound 4, half-maximal inhibitory concentration: 2810 nM
Compound 4: middle estimate off by 8.9-fold (0.95 log units), on the high side; the measured number lies below the stated range.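

In this assay, the change from 3,4-dimethoxyphenyl to 3,4,5-trimethoxyphenyl gives a 5.6-fold lower number from compound 3 to compound 4 (0.75 log units; beyond the scatter), a gain in potency that is beyond the scatter. Placing a methoxy in place of a hydrogen on an aromatic carbon therefore cannot be carried from one core to the other as a fixed increment, as the two steps show: the same change on two cores in this assay, a 2.0-fold higher number (0.30 log units; within the scatter) from compound 1 to compound 2 and a 5.6-fold lower number (0.75 log units; beyond the scatter) from compound 3 to compound 4, 11-fold (1.05 log units) apart, beyond the scatter of two such steps This does not show that the core alone sets the outcome, since there is only one pair on each core and the entering methoxy of compound 4 is meta to a methoxy group, which was not so in compound 2.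

The compounds shown leave open how the 3,4,5-trimethoxyphenyl group would behave on the core of compound 1, which would separate the effect of the core from that of the substitution pattern. They also leave open whether an ethoxy group, a hydroxyl or an amine at the place of the entering methoxy would follow compound 4.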